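A Chlorobenzyl Amine Variant and Its Expected Stability

A few compounds are considered here, and "the series" means these few. Any claim that something is new, unique, unknown or untested is made for them only; others in the source may bear on it.

compound 1 `Cc1csc2cc([C@H](C)Nc3ncnc(N)c3C#N)c(-c3cccc(CN4CCC(CN(C)Cc5ccccn5)CC4)c3)c(=O)n12`: 5.2%
compound 2 `Cc1csc2cc([C@H](C)Nc3ncnc(N)c3C#N)c(-c3cccc(CN(C)CCCCN(C)Cc4ccccc4)c3)c(=O)n12`: 7.4%
compound 3 `Cc1csc2cc([C@H](C)Nc3ncnc(N)c3C#N)c(-c3ccccc3)c(=O)n12`: 0%

In an ADME assay on the whole organism (lung, Rattus norvegicus) for metabolic stability, read by LC-MS, with a stated time of 24 h (a lower number here means that less of the compound is left, a higher number that more of the compound is left), compound 2 gives 7.4%. The numbers for compound 1 and compound 3 lie within the usual scatter of the number for compound 2, so none of the three stands apart from the others in this assay; all three leave little of the compound behind.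

Compound 4 `Cc1csc2cc([C@H](C)Nc3ncnc(N)c3C#N)c(-c3cccc(CN(C)CCCN(C)Cc4ccc(Cl)cc4)c3)c(=O)n12` carries (4-chlorobenzyl)(methyl)amino in place of (benzyl(methyl)amino)methyl on a saturated chain carbon, three bonds along the chain from an amine nitrogen. Among the compounds with values here, no step between measured compounds is known for this kind of change, and the three measured numbers give no hint of a move beyond the scatter. Compound 4 is therefore expected to stay close to compound 2, with an estimated step of a number 1.4 percentage points lower from compound 2 to compound 4 (within the scatter). The estimate for compound 4 is 6%, in a range from 0% to 15%.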

Compound 4, percent of the compound remaining: 3.3%
Compound 4: middle estimate off by 2.7 percentage points, on the high side, and the stated range covers the measured number.
By their numbers in this assay, from the lowest: compounds 3, 4, 1 and 2 (each within the scatter of the next).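

In this assay, (4-chlorobenzyl)(methyl)amino in place of (benzyl(methyl)amino)methyl on a saturated chain carbon, three bonds along the chain from an amine nitrogen, gives the first step read at this position (a number 4.1 percentage points lower from compound 2 to compound 4 (within the scatter)). This change therefore does not carry the read-out beyond the scatter, although both a chlorine and a change in the chain enter together. Nothing measured here bears on the reason for this result. The compounds shown leave open what the chlorine and the chain change each do alone. They also leave open whether a fluorine or a methoxy group on the benzyl ring, or a carboxylic acid on the chain, would stay within the scatter.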